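The source may report more compounds than this note shows. Statements on the series, on what has been measured and on what is new or still open speak of the compounds shown alone.

Compound 1 `CCCn1c(=O)[nH]c2nc(-c3ccc(S(=O)(=O)N4CCN(c5ccc(Br)cc5)CC4)cc3)[nH]c2c1=O` is among two closely related compounds tested in an assay on CHO cells for displacement of a labelled ligand from adenosine receptor A1 (Homo sapiens), read by scintillation counting, with a stated time of 90 min, in the presence of a further agent that is not named here; on this read-out lower numbers stand for stronger inhibition and higher numbers for weaker inhibition. Compound 1 gives only a limit there, > 1000 nM, not a number. Compound 2 `CCCn1c(=O)[nH]c2nc(-c3ccc(S(=O)(=O)N4CCN(c5ccccc5)C(C)C4)cc3)[nH]c2c1=O` likewise gives only a limit in this assay, > 1000 nM. Where compound 1 stands is thus told only by the limit of > 1000 nM in this assay, at which 2 of the 2 values shown sit. Compound 3 `CCCn1c(=O)[nH]c2nc(-c3ccc(S(=O)(=O)N4CCN(c5ccccc5)CC4)cc3)[nH]c2c1=O` differs from compound 1 by hydrogen in place of bromo on an aromatic carbon. Among the measured compounds shown here, no measured step covers such a change, so the expected step in this assay is none beyond the scatter. Compound 3 is expected to give about 3000 nM, within 800 nM to 20000 nM. The expected step is a step that the limit leaves unreadable from compound 1 to compound 3, most likely again reported as a limit.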

Compound 3, inhibition constant: 364 nM
For compound 3 the middle estimate is 8.2-fold (0.92 log units) above the measured one; measured number below the stated range.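

In this assay, going from 4-bromophenyl to phenyl gives an at least 2.7-fold lower number from compound 1 to compound 3 (0.43 log units; beyond the scatter), so in this pair bromo at this place is worse for binding than hydrogen. Hydrogen in place of methyl on a saturated ring carbon, a change elsewhere in the molecule, gives an at least 2.7-fold lower number from compound 2 to compound 3 (0.43 log units; beyond the scatter), so both added groups weaken binding compared with compound 3. Both steps are only minimum sizes because each starting compound sits at a limit, not a number: the limit of > 1000 nM in this assay, at which 2 of the 3 values shown sit.

Going by these compounds, it remains open whether a smaller group such as fluoro or a different one such as methoxy would be accepted at this place. On these data alone, the true size of each step also remains unknown.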